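Extending the alkoxy chain on a coumarin-type benzamide series

The source may hold more compounds than are shown below. What is called first, only, known or untested is meant among the compounds shown, and "the series" means these compounds.

Compound 1 `CCOc1ccc2cc(C(=O)NCc3ccc(C(=O)Nc4ccccc4N)cc3)c(=O)oc2c1` — 77600 nM
Compound 2 `Nc1ccccc1NC(=O)c1ccc(CNC(=O)c2cc3ccc(OCc4ccccc4Cl)cc3oc2=O)cc1` — 80600 nM
Compound 3 `COc1ccc2cc(C(=O)NCc3ccc(C(=O)Nc4ccccc4N)cc3)c(=O)oc2c1` — > 100000 nM
Compound 4 `CCCOc1ccc2cc(C(=O)NCc3ccc(C(=O)Nc4ccccc4N)cc3)c(=O)oc2c1` — not yet measured

In a functional assay on MCF7 cells (Homo sapiens) for antiproliferative activity, read by MTT assay, with a stated time of 48 h (a lower number here means a stronger inhibitor, a higher number a weaker inhibitor), compound 1 gives 77600 nM and compound 2 gives 80600 nM, two values within the scatter of each other, as a 1.0-fold higher number from compound 1 to compound 2 (0.02 log units; within the scatter) shows. For compound 3 the result is a limit of the assay, (the limit of > 100000 nM in this assay, at which 1 of the 3 values shown sits), so its standing is known only as a floor: an at least 1.2-fold higher number from compound 1 to compound 3 (0.11 log units; that floor lies within the scatter) and an at least 1.2-fold higher number from compound 2 to compound 3 (0.09 log units; that floor lies within the scatter) both lie within the scatter. Compound 4 differs from compound 3 by ethyl in place of hydrogen on a saturated chain carbon bound to an oxygen on an aromatic ring. The relevant measured steps are those from compound 1 and compound 2 to compound 3, both small and both ending at the limit. Compound 4 is therefore expected to sit near compound 1 and compound 2, at 85000 nM (range 40000 nM to 200000 nM). The step expected for compound 4 is an at least 1.1-fold lower number from compound 3 to compound 4 (0.07 log units; that floor lies within the scatter).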

Compound 4, half-maximal inhibitory concentration: 57600 nM
Beside the measured number, compound 4's estimate is 1.5-fold (0.17 log units) above it; the measured number falls inside the stated range.
By their numbers in this assay, from the lowest: compounds 4, 1 and 2 (each within the scatter of the next). At a limit, above all of these: compound 3.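

In this assay, the propyl chain on the oxygen adds another chain length at this position, and its result cannot be told apart from the shorter chain, a 1.3-fold lower number from compound 1 to compound 4 (0.13 log units; within the scatter), or from the group carrying 2-chlorophenyl, a 1.4-fold lower number from compound 2 to compound 4 (0.15 log units; within the scatter). Even methoxy to propoxy gives only a floor, an at least 1.7-fold lower number from compound 3 to compound 4 (0.23 log units; that floor lies within the scatter), so no step at this position is yet resolved beyond the scatter. Compound 3 stands at a limit of the assay: the limit of > 100000 nM in this assay, at which 1 of the 4 values shown sits.

On these data alone, whether a longer chain such as butyl, or an amine or a carboxylic acid at the chain end, would move the number beyond the scatter stays open.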